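Amino for Chloro in Two Benzyl Isomers

The compounds below may be only part of what the source reports. "The series", "measured", "known", "first", "only" and "open" are said of these compounds alone.

Compound 1 `ClCc1ccccc1Cn1cnc2c(Cl)nc(Cl)nc21` and compound 2 `ClCc1cccc(Cn2cnc3c(Cl)nc(Cl)nc32)c1` are built from the same atoms joined differently; how their two cores differ is not broken down here. In a functional assay on CCRF-CEM cells (Homo sapiens) for cytotoxicity, read by sulforhodamine B assay, with a stated time of 48 h (on this read-out lower numbers stand for stronger inhibition of growth and higher numbers for weaker inhibition of growth), compound 1 gives 30 nM, while compound 2 gives 2690 nM. Compound 3 `Nc1nc(Cl)c2ncn(Cc3ccccc3CCl)c2n1` arises from compound 1 by a single change, (amino in place of chloro on an aromatic carbon), and in this assay compound 3 gives 17800 nM, so that the step is a 590-fold higher number from compound 1 to compound 3 (2.77 log units; beyond the scatter). Compound 4 `Nc1nc(Cl)c2ncn(Cc3cccc(CCl)c3)c2n1` is not yet measured; it arises from compound 2 by the same change at the same place, (amino in place of chloro on an aromatic carbon). Because the earlier step of a 590-fold higher number from compound 1 to compound 3 (2.77 log units; beyond the scatter) was so large, a step of similar size is expected here, a 74-fold higher number from compound 2 to compound 4 (1.87 log units; beyond the scatter), though it rests on one example only. Compound 4 is therefore expected to give about 200000 nM, with a likely range from 20000 nM to 1500000 nM.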

Compound 4, concentration for 50% growth inhibition: 3020 nM
Compound 4: middle estimate off by 66-fold (1.82 log units), on the high side; measured number below the stated range.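

In this assay, the change from chloro to amino gives a 1.1-fold higher number from compound 2 to compound 4 (0.05 log units; within the scatter), so on the core of compound 2 it makes no difference that can be told from the scatter. A change that is large on one core therefore need not be large on a closely related one, as the two steps set side by side show: the same change on two cores in this assay, a 590-fold higher number (2.77 log units; beyond the scatter) from compound 1 to compound 3 and a 1.1-fold higher number (0.05 log units; within the scatter) from compound 2 to compound 4, 530-fold (2.72 log units) apart, beyond the scatter of two such steps

This does not show why the two cores respond so differently, and two pairs give no rule for any further core. The compounds shown leave open whether a methoxy group or a methylamino group in the same place would also separate the two cores. They also leave open whether the same gap would appear in a different cell line.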